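A Methoxy Swap in a Flat Series

The source may report more compounds than this note shows. Statements on the series, on what has been measured and on what is new or still open speak of the compounds shown alone.

Of the compounds shown here, three that share one core have been tested in a functional assay on the whole organism for positive allosteric modulation, with Rattus norvegicus as the target; on this read-out lower numbers stand for an effect already at smaller amounts and higher numbers for an effect only at larger amounts of compound. Compound 1 `Cc1nn(C)c2c1C(c1ccccc1)=NCCN2` carries no added group on its six-membered aromatic ring of carbon only, and in this assay compound 1 gives 2.5 mg/kg. Compound 2 `Cc1nn(C)c2c1C(c1ccc(Cl)cc1)=NCCN2` adds a chloro group to that ring, and compound 2 gives 2.5 mg/kg. Compound 3 `Cc1ccc(C2=NCCNc3c2c(C)nn3C)cc1` carries a methyl group instead, and compound 3 gives 2.5 mg/kg. The steps between them are all flat: no change at the digits printed from compound 1 to compound 2 (within the scatter), no change at the digits printed from compound 1 to compound 3 (within the scatter) and no change at the digits printed from compound 2 to compound 3 (within the scatter). Compound 3 therefore stands level with compounds 1 and 2.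

Compound 4 `COc1ccc(C2=NCCNc3c2c(C)nn3C)cc1` continues the series with a single change: methoxy in place of methyl on an aromatic carbon The steps of no change at the digits printed from compound 1 to compound 3 (within the scatter) and no change at the digits printed from compound 2 to compound 3 (within the scatter) bear on it most closely; each swaps a group at this same position, and neither moved the read-out. With every measured step flat, no change beyond the scatter is expected, and the expected step of no change at the digits printed from compound 3 to compound 4 (within the scatter) is correspondingly small. Compound 4 is therefore estimated at 2.5 mg/kg, with a range from 1.2 mg/kg to 5 mg/kg.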

Compound 4, minimum effective dose: > 10 mg/kg
Compound 4 was reported as a limit (the forecaster's own chance of this, stated with the estimate: 5%); middle value at least 4.0-fold (0.60 log units) away from the limit.
By their numbers in this assay, from the lowest: compounds 1, 2 and 3 (each within the scatter of the next). At a limit, above all of these: compound 4.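

This position is not indifferent to every change: hydrogen, chloro and methyl sit level here, but methoxy does not join them, giving an at least 4.0-fold higher number from compound 3 to compound 4 (0.60 log units; beyond the scatter), an at least 4.0-fold higher number from compound 2 to compound 4 (0.60 log units; beyond the scatter) and an at least 4.0-fold higher number from compound 1 to compound 4 (0.60 log units; beyond the scatter). In this assay compound 4 gives > 10 mg/kg, which is a limit and not a number. Each of these steps therefore gives only a minimum size, and the true gap could be larger: the limit of > 10 mg/kg in this assay, at which 1 of the 4 values shown sits.

The compounds shown leave open whether the change in the read-out follows the oxygen of methoxy or simply a group with more heavy atoms than methyl. An ethyl group, which has no oxygen, or a hydroxyl group, which has oxygen without the added carbon, would help to separate these two readings at this same place.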